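From methoxycarbonyl to hydroxymethyl on compound 3

This account rests on a few compounds, and the source may have more. Where it says the series, first, only, none or still open, it means among the compounds named here.

Measured in an ADME assay on BAEC cells (Bos taurus) for cytotoxicity, read by MTT assay, with a stated time of 2 days; on this read-out higher numbers stand for weaker inhibition and lower numbers for stronger inhibition (each value is a limit, not a number):
- compound 1 `COc1c(Br)cc(CO)c(O)c1Br` gives > 16000 nM
- compound 2 `COc1c(Br)cc(CO)c(OCc2ccccc2)c1Br` gives > 12000 nM
- compound 3 `COC(=O)COc1c(CO)cc(Br)c(OC)c1Br` gives > 26000 nM

Compound 3 therefore stands at a limit, as do the other two compounds. Compound 4 `COc1c(Br)cc(CO)c(OCCO)c1Br` carries hydroxymethyl in place of methoxycarbonyl on a saturated chain carbon bound to an oxygen on an aromatic ring, counted as hydroxymethyl in place of methoxycarbonyl on a saturated chain carbon bound to an oxygen on an aromatic ring and turning (methoxycarbonyl)methyl into 2-hydroxyethyl. Two measured changes at this oxygen bear on it, a step that the two limits leave unreadable from compound 1 to compound 3 and a step that the two limits leave unreadable from compound 2 to compound 3 and neither has a readable size. Within the data shown here, no step of known size or direction is thus expected in this assay here. The expected change is a step that the limit leaves unreadable from compound 3 to compound 4 and it remains only an estimate. For compound 4 the estimated value is 28000 nM with an expected range of 12000 nM to 70000 nM and a limit is the likeliest report.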

Compound 4, half-maximal inhibitory concentration: > 28000 nM
Compound 4: only a limit was reported; the forecaster's own chance of this, stated with the estimate: 85%; the middle value lies on the limit itself.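

Among these compounds, compound 1, compound 2, compound 3 and compound 4 are all reported only as limits, so no step to compound 4 can be read. On these data alone, whether hydroxymethyl in place of methoxycarbonyl changes the read-out at all stays open.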